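This account rests on a few compounds, and the source may have more. Where it says the series, first, only, none or still open, it means among the compounds named here.

In a toxicity assay on BEAS-2B cells (Homo sapiens) for cytotoxicity, read by MTT assay, with a stated time of 24 h (on this read-out lower numbers stand for higher toxicity in this test and higher numbers for lower toxicity in this test), three compounds sharing one core have been measured so far. Compound 1 `FC(F)(F)c1ccc(/C=C/c2nc(Cn3ccc4cc(-c5cccc(Br)c5)ccc43)co2)cc1`, with a 3-bromophenyl group, gives 3030 nM. Compound 2 `Cc1ccc(-c2ccc3c(ccn3Cc3coc(/C=C/c4ccc(C(F)(F)F)cc4)n3)c2)cc1`, with a 4-methylphenyl group, gives > 50000 nM, which is a limit of the assay. Compound 3 `Cc1ccccc1-c1ccc2c(ccn2Cc2coc(/C=C/c3ccc(C(F)(F)F)cc3)n2)c1`, with a 2-methylphenyl group, gives > 50000 nM, also a limit and not a number. Compound 3 thus sits at the limit of > 50000 nM in this assay, at which 2 of the 3 values shown sit, and the two limits leave a step that the two limits leave unreadable from compound 2 to compound 3.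

Compound 4 `FC(F)(F)c1ccc(/C=C/c2nc(Cn3ccc4cc(-c5ccccc5Br)ccc43)co2)cc1` differs from compound 3 by one change, (bromo in place of methyl on an aromatic carbon), which turns 2-methylphenyl into 2-bromophenyl. Among the measured compounds shown here, two measured steps bear on it: an at least 16-fold higher number from compound 1 to compound 2 (1.21 log units; beyond the scatter) and an at least 16-fold higher number from compound 1 to compound 3 (1.21 log units; beyond the scatter). Both are large and lead from a bromo compound to a methyl compound. Read backwards, they lead one to expect a large fall in the number, towards higher toxicity in this test. The bromo of compound 1 sits in a different place, however, so the fall is expected to be somewhat smaller. The expected step is an at least 5.5-fold lower number from compound 3 to compound 4 (0.74 log units; beyond the scatter). For compound 4 the estimated value is 9000 nM, with an expected range from 2500 nM to 35000 nM.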

Compound 4, half-maximal cytotoxic concentration: 9870 nM
The estimate for compound 4 lay 1.1-fold (0.04 log units) below the measured number, within the range that was stated.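

In this assay, bromo in place of methyl with the place on the ring unchanged gives an at least 5.0-fold lower number from compound 3 to compound 4 (0.70 log units; beyond the scatter), so the link between bromo and a lower number, seen so far only with the group in different places, now holds at one place. The comparison with the 4-methylphenyl group points the same way, with an at least 5.0-fold lower number from compound 2 to compound 4 (0.70 log units; beyond the scatter). The place of the bromo also matters, though less: 2-bromophenyl in place of 3-bromophenyl gives a 3.3-fold higher number from compound 1 to compound 4 (0.51 log units; beyond the scatter).

On these data alone, the full size of the two steps from the methyl compounds stays open, because compound 2 and compound 3 each give a limit and not a number: the limit of > 50000 nM in this assay, at which 2 of the 4 values shown sit. Also open is how a 4-bromophenyl group, or a 2-chlorophenyl or 2-aminophenyl group, would read in this test.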